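Series notes: anilide chain variation and cytotoxicity

The compounds below may be only part of what the source reports. "The series", "measured", "known", "first", "only" and "open" are said of these compounds alone.

Measured so far:
- compound 1, `CCCNc1ccc(NC(=O)c2cc(Cl)ccc2O)c(Cl)c1`: 22500 nM
- compound 2, `CC1(Nc2ccc(NC(=O)c3cc(Cl)ccc3O)c(Cl)c2)CCCC1`: 157000 nM
- compound 3, `COc1ccc(CNc2ccc(NC(=O)c3cc(Cl)ccc3O)c(Cl)c2)cc1`: 80700 nM

All three share the same core and differ only in the group on the aniline nitrogen. In an ADME assay on A549 cells (Homo sapiens) for cytotoxicity, read by resazurin assay, with a stated time of 48 h (a lower number here means that less compound is tolerated, a higher number that more compound is tolerated), compound 1 gives the lowest number of the three, and the two bulkier groups give higher numbers: a 7.0-fold higher number from compound 1 to compound 2 (0.84 log units; beyond the scatter) and a 3.6-fold higher number from compound 1 to compound 3 (0.55 log units; beyond the scatter). Compound 2 and compound 3 cannot be ordered against each other, since a 1.9-fold lower number from compound 2 to compound 3 (0.29 log units; within the scatter). Compound 3 thus stands second highest of three numbers, close to compound 2 and clearly apart from compound 1.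

Compound 4, `CC(C)(C)OC(=O)NCCNc1ccc(NC(=O)c2cc(Cl)ccc2O)c(Cl)c1`, is the next step from compound 3. The change is ((tert-butoxycarbonyl)amino)methyl in place of 4-methoxyphenyl on a saturated chain carbon bound to a nitrogen on an aromatic ring. Among the measured compounds shown here, the only measured step that touches this position is a 3.6-fold higher number from compound 1 to compound 3 (0.55 log units; beyond the scatter), which suggests that the substituent on this chain carbon matters at a modest level, but no measured compound carries an acyclic, donor-bearing group of this kind, so the direction is uncertain. On balance compound 4 is expected to stay near compound 3, with an estimated step of a 1.3-fold lower number from compound 3 to compound 4 (0.13 log units; within the scatter) in this assay. The expected value for compound 4 is therefore 60000 nM, with a range from 20000 nM to 180000 nM.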

Compound 4, half-maximal cytotoxic concentration: 25000 nM
Beside the measured number, compound 4's estimate is 2.4-fold (0.38 log units) above it, within the range that was stated.
By their numbers in this assay, from the lowest: compounds 1 and 4 (each within the scatter of the next); then compounds 3 and 2 (each within the scatter of the next).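

In this assay, ((tert-butoxycarbonyl)amino)methyl in place of 4-methoxyphenyl on a saturated chain carbon bound to a nitrogen on an aromatic ring gives a 3.2-fold lower number from compound 3 to compound 4 (0.51 log units; beyond the scatter), so the higher number of compound 3 does not carry over to every group of similar heavy-atom count at this place (9 entering, 8 leaving). The second step, a 1.1-fold higher number from compound 1 to compound 4 (0.05 log units; within the scatter), shows that (tert-butoxycarbonyl)amino in place of methyl leaves the number within the scatter, so in this pair a much larger chain end brings no measurable change, whereas the 4-methoxyphenyl end of compound 3 stands apart from the ethyl end of compound 1. Nothing at hand gives a reason for either step.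

Open, from the compounds shown here alone, is whether the ring of 4-methoxyphenyl is what separates compound 3 from compound 4, or whether the acyclic replacement as a whole matters. A free primary amine or a carboxylic acid at the end of the same chain, a longer alkyl chain, or an unsubstituted phenyl group would help to separate these readings.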